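From 4-Methylbenzyl to 3,4-Dichlorobenzyl on the Shared Core

The source may hold more compounds than are shown below. What is called first, only, known or untested is meant among the compounds shown, and "the series" means these compounds.

In a functional assay on K562 cells (Homo sapiens) for antiproliferative activity, with a stated time of 72 h (a higher number here means a weaker inhibitor, a lower number a stronger inhibitor), compound 1 `OC[C@H]1O[C@@H](n2cnc3c(NCc4ccc(Cl)cc4)ncnc32)[C@H](O)[C@@H]1O` gives 218000 nM. Compound 2 `Cc1ccc(CNc2ncnc3c2ncn3[C@@H]2O[C@H](CO)[C@@H](O)[C@H]2O)cc1` is reported only as > 166000 nM, which is a limit and not a number. Compound 2 therefore has no readable place on the scale, and the evidence amounts to the limit of > 166000 nM in this assay, at which 1 of the 2 values shown sits. Going by the values given here, the single measured step, a step that the limit leaves unreadable from compound 1 to compound 2, puts methyl in place of chloro on an aromatic carbon, and it offers no size to carry forward.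

Compound 3 `OC[C@H]1O[C@@H](n2cnc3c(NCc4ccc(Cl)c(Cl)c4)ncnc32)[C@H](O)[C@@H]1O` brings 3,4-dichlorophenyl in place of the 4-methylphenyl of compound 2, on a saturated chain carbon bound to a nitrogen on an aromatic ring: 3,4-dichlorophenyl in place of 4-methylphenyl on a saturated chain carbon bound to a nitrogen on an aromatic ring. Like compound 1, it carries chloro on that ring, so the only numerical anchor is compound 1 at 218000 nM. In this assay, compound 3 is therefore expected to remain a weak inhibitor, with at most a small shift towards stronger inhibition. The expected change is an at least 1.3-fold lower number from compound 2 to compound 3 (0.14 log units; that floor lies within the scatter). Compound 3 is estimated at 120000 nM, with an expected range of 40000 nM to 300000 nM.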

Compound 3, half-maximal inhibitory concentration: 10800 nM
Compound 3: the middle estimate sits 11-fold (1.05 log units) above what was measured, and the stated range ends above it.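

Chloro in place of hydrogen on an aromatic carbon, which turns the 4-chlorobenzyl group of compound 1 into the 3,4-dichlorobenzyl group, gives in this assay a 20-fold lower number from compound 1 to compound 3 (1.31 log units; beyond the scatter), so this ring of the shared core is a place where a single change moves the number well beyond the scatter, something the earlier pair could not show. The comparison with the 4-methylbenzyl group points the same way, with an at least 15-fold lower number from compound 2 to compound 3 (1.18 log units; beyond the scatter), and that size is a floor and not an exact figure. The value of compound 2 is a limit, which leaves the earlier step from compound 1 unreadable and gives this comparison only one firm end: the limit of > 166000 nM in this assay, at which 1 of the 3 values shown sits.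

The compounds shown leave open whether the large step needs both chloro groups together or whether the 3-chlorobenzyl group alone would give it. They also leave open whether bromo, methoxy or trifluoromethyl in place of chloro on this ring would keep the lower number in this assay, and they give no reason for the step.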